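Chain extension from compound 2 to compound 3

The source may hold more compounds than are shown below. What is called first, only, known or untested is meant among the compounds shown, and "the series" means these compounds.

Measured in a functional assay on EC9706 cells (Homo sapiens) for antiproliferative activity, read by MTT assay, with a stated time of 48 h; a higher number here means a weaker inhibitor, a lower number a stronger inhibitor:
- compound 1 `CCCCCCCCCn1cc(COC[C@@H]2OC[C@H](N)[C@@H]2O)nn1`: 20100 nM
- compound 2 `CCCCCCCCCCCCCCn1cc(COC[C@@H]2OC[C@H](N)[C@@H]2O)nn1`: 7830 nM

Among the compounds with values here, compound 2 holds the lower of the two numbers, and so the best position so far. The change to compound 3 `CCCCCCCCCCCCCCCCCCn1cc(COC[C@@H]2OC[C@H](N)[C@@H]2O)nn1` is butyl in place of hydrogen on a saturated chain carbon, ten or more bonds along the chain from an aromatic nitrogen. Within the data shown here, one measured step bears on this, also a chain extension: a 2.6-fold lower number from compound 1 to compound 2 (0.41 log units; beyond the scatter). A further lowering of similar or smaller size is therefore expected in this assay, although a single step cannot show whether the trend continues. The expected change is a 1.6-fold lower number from compound 2 to compound 3 (0.19 log units; within the scatter). The estimated value for compound 3 is 5000 nM, with an expected range of 2000 nM to 14000 nM.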

Compound 3, half-maximal inhibitory concentration: 17800 nM
Compound 3: middle estimate off by 3.6-fold (0.55 log units), on the low side, and the stated range ends below it.
By their numbers in this assay, from the lowest: compound 2; then compounds 3 and 1 (each within the scatter of the next).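

In this assay the direction at this place turns with butyl in place of hydrogen (a 2.3-fold higher number from compound 2 to compound 3 (0.36 log units; beyond the scatter)), so the lowering seen earlier does not carry on past compound 2. The longest chain also gains nothing over the shortest (a 1.1-fold lower number from compound 1 to compound 3 (0.05 log units; within the scatter)), leaving compound 2 with the lowest number of the three, beyond the scatter of both others. No measurement offered here bears on why the direction turns.

Still open, going by these compounds, is where the lowest number falls for chains between those of compound 2 and compound 3. An amine or a carboxylic acid in place of butyl also remains untested among the compounds shown.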